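A few compounds are considered here, and "the series" means these few. Any claim that something is new, unique, unknown or untested is made for them only; others in the source may bear on it.

Measured so far in an ADME assay on Vero cells (Chlorocebus sabaeus) for cytotoxicity, read by resazurin assay, with a stated time of 72 h; a higher number here means a weaker inhibitor, a lower number a stronger inhibitor:
- compound 1 `Cc1ccc(C(=O)CCN2CCN(c3ccc(F)cc3)CC2)cc1` (value 55400 nM)
- compound 2 `Cc1ccc(C(=O)CCN2CCN(c3ccc([N+](=O)[O-])cc3)CC2)cc1` (value 235000 nM)

Of these two, compound 1 has the lower number and so is the stronger inhibitor in this assay here. The next compound, compound 3 `O=C(CCN1CCN(c2ccc(F)cc2)CC1)c1ccc(OC(F)(F)F)cc1`, keeps the core of compound 1 with trifluoromethoxy in place of methyl on an aromatic carbon, para to a large group (trifluoromethoxy in place of methyl on an aromatic carbon). Within the data shown here, only one measured step is available, a 4.2-fold higher number from compound 1 to compound 2 (0.63 log units; beyond the scatter), a modest change beyond the scatter. That step put nitro in place of fluoro and left the methyl untouched, so it gives only a rough sense of how far one swapped group can move this number. No measurement shows what replacing the methyl does, so neither direction is favoured and no step beyond the scatter is expected. The estimated change is a 1.1-fold lower number from compound 1 to compound 3 (0.04 log units; within the scatter) and carries a wide margin. For compound 3 the expected value is 50000 nM, with an estimated range from 20000 nM to 125000 nM.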

Compound 3, half-maximal inhibitory concentration: 70300 nM
The estimate for compound 3 lay 1.4-fold (0.15 log units) below the measured number, within the range that was stated.
By their numbers in this assay, from the lowest: compounds 1 and 3 (each within the scatter of the next); then compound 2.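

In this assay, putting trifluoromethoxy in place of methyl on the aromatic carbon para to a large group gives a 1.3-fold higher number from compound 1 to compound 3 (0.10 log units; within the scatter), so the two compounds cannot be told apart. Among these compounds, this is the first look at this position: a group of five heavy atoms, carrying a hydrogen-bond acceptor, stands where a single carbon stood, with no step beyond the scatter, whereas the earlier step changed fluoro to nitro and left the methyl untouched. Nothing measured here bears on why this swap has so little effect.

One swap cannot show how this position responds in general, so an amine or a carboxylic acid at the same place remains an open case. Also open, as far as these compounds go, is whether trifluoromethoxy would give a similar result on the nitro-bearing compound 2.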